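A few compounds are considered here, and "the series" means these few. Any claim that something is new, unique, unknown or untested is made for them only; others in the source may bear on it.

Measured compounds in a functional assay on A549 cells (Homo sapiens) for cytotoxicity, read by MTT assay, with a stated time of 72 h; on this read-out lower numbers stand for stronger inhibition and higher numbers for weaker inhibition:
compound 1, `Cc1ccc2[nH]c(-c3ccc[nH]3)c(C3CC(=O)NC3=O)c2c1`, gives 20000 nM;
compound 2, `COc1ccc2[nH]c(-c3ccc[nH]3)c(C3CC(=O)NC3=O)c2c1`, gives 4000 nM;
compound 3, `COc1ccc2[nH]c3c(c4c(n5cccc35)C(=O)N(C)C4=O)c2c1`, gives 36000 nM.

Compound 2 gives the lowest number of the three. For the measured compounds named here, the nearest to it is compound 1, and the only single-point step in the set, a 5.0-fold lower number from compound 1 to compound 2 (0.70 log units; beyond the scatter), came with methoxy in place of methyl on an aromatic carbon. Going by the values given here, compound 3 stands furthest away with the highest number of the three, and it differs from compound 2 at several places at once, so no single step links them.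

Compound 4, `COc1ccc2[nH]c(-c3ccc[nH]3)cc2c1`, has not yet been measured. It differs from compound 2 by hydrogen in place of 2,5-dioxopyrrolidin-3-yl on an aromatic carbon. Among the compounds with values here, no measured step touches this group: the one step in hand, a 5.0-fold lower number from compound 1 to compound 2 (0.70 log units; beyond the scatter), concerns a different position, and compound 3 offers no clean comparison. The data therefore give no direct guide to the size or direction of the change, and the expectation below rests on the absence of any evidence that the group can be removed without cost, so a wide range is kept. For compound 4 the estimate in this assay is 15000 nM, with a range from 3000 nM to 80000 nM. This estimate corresponds to an expected step of a 3.8-fold higher number from compound 2 to compound 4 (0.57 log units; beyond the scatter).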

Compound 4, half-maximal inhibitory concentration: 55000 nM
For compound 4 the middle estimate is 3.7-fold (0.56 log units) below the measured one; the range from low to high includes it.
By their numbers in this assay, from the lowest: compound 2; then compounds 1, 3 and 4 (each within the scatter of the next, the first and the last beyond it).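

In this assay, for the compounds shown here, hydrogen in place of 2,5-dioxopyrrolidin-3-yl on the aromatic carbon gave a 14-fold higher number from compound 2 to compound 4 (1.14 log units; beyond the scatter), the first step at this position and a large one beside the modest 5.0-fold lower number from compound 1 to compound 2 (0.70 log units; beyond the scatter) at the other position. Going by these compounds alone, the earlier compounds could not show that this position mattered, but this pair shows that, with the methoxy group held in place, the lowest number of the set depends on what sits on this carbon, and that simply removing the group costs more than the one change seen elsewhere on the core. No measurement available here bears on the reason for the size of this step.

The compounds shown leave open which part of the departing group matters, since the whole ring left in one change and the ring carbonyls and the amide hydrogen were not separated from one another. They also leave open how a carboxylic acid, a primary amine or a short acetamide chain on this same carbon would compare, and whether the same loss would appear on the methyl-bearing core of compound 1.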